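The source may hold more compounds than are shown below. What is called first, only, known or untested is meant among the compounds shown, and "the series" means these compounds.

Compound 2 `C1=C(c2cccnc2)C[C@H]2CNC[C@@H]1C2` stands at the low end of the two numbers recorded in an in vitro assay on HEK-293T cells for displacement of a labelled ligand from Neuronal acetylcholine receptor; alpha3/alpha6/beta2/beta3 (Homo sapiens); a higher number here means a weaker inhibitor, a lower number a stronger inhibitor: compound 2 gives 0.95 nM, while its methylated counterpart compound 1 `CN1C[C@H]2C=C(c3cccnc3)C[C@H](C2)C1` gives 300 nM in this assay. Going by the values given here, the one step measured so far, a 320-fold lower number from compound 1 to compound 2 (2.50 log units; beyond the scatter), came with a hydrogen in place of a methyl on the amine nitrogen in the ring.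

Compound 3 `C1=C(c2cccnc2)C[C@@H]2CNC[C@H]1C2` is a different matter: relative to compound 2, (the two compounds have the same atoms and bonds and differ only in configuration as drawn: 2 of 2 stereo elements differ (all stereocentres are inverted: mirror images); a stereocentre at a saturated ring carbon is drawn S in compound 2 and R in compound 3; a stereocentre at a saturated ring carbon is drawn R in compound 2 and S in compound 3). Among the compounds with values here, no measured step bears on an inversion of configuration, so the large step seen from compound 1 to compound 2 offers no direct guide, and the expectation rests on the observation that compound 3 keeps every atom and bond of compound 2 but presents them as the mirror image. For a ligand this potent, the mirror image is usually, though not always, the weaker of the pair, so a step of an 8.4-fold higher number from compound 2 to compound 3 (0.93 log units; beyond the scatter) toward a higher number is expected. Compound 3 is therefore estimated at 8 nM in this assay, within a range of 1.5 nM to 60 nM.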

Compound 3, inhibition constant: 1 nM
For compound 3 the middle estimate is 8.0-fold (0.90 log units) above the measured one, and the stated range ends above it.
By their numbers in this assay, from the lowest: compounds 2 and 3 (each within the scatter of the next); then compound 1.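

Inverting both stereocentres gives, in this assay, a 1.1-fold higher number from compound 2 to compound 3 (0.02 log units; within the scatter), so with a hydrogen on the amine nitrogen in the ring, this assay does not separate the two mirror images. Going by these compounds alone, until now, the only change on record was the one at that nitrogen, where a 320-fold lower number from compound 1 to compound 2 (2.50 log units; beyond the scatter) showed how far the number can move; a full inversion of configuration now stands as a change that does not carry the number beyond the scatter. The comparison is a clean test of configuration alone, as nothing else separates the pair: the fact that compounds 2 and 3 differ only in the configuration as drawn

Within the data shown here, whether the mirror images would remain within the scatter of each other with a methyl or an ethyl group on the amine nitrogen in the ring remains open, since the single comparison of mirror images here has a hydrogen at that place. Also open, as far as these compounds go, is whether the same would hold with a chlorine added to the shared core, or at any other receptor.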